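Nitrile replaced on the side chain of compound 1

This account rests on a few compounds, and the source may have more. Where it says the series, first, only, none or still open, it means among the compounds named here.

Measured so far:
compound 1 `Cc1ccc(=O)n(CCC#N)n1` — 0.2%
compound 2 `CC(CC(=N)S)n1nc(-c2ccccc2)ccc1=O` — 15.5%

In a functional assay on the whole organism (stomach) for inhibition, with Rattus norvegicus as the target, at a dose of 100 mg/kg by the intraduodenal route (on this read-out lower numbers stand for less inhibition and higher numbers for more inhibition at the one dose given (going by the name of the read-out)), compound 1 gives 0.2%, the lowest of the two numbers in hand. Among the measured compounds shown here, its nearest neighbour is compound 2, which in this assay gives 15.5%; the two differ by more than the scatter, but they also differ in several places at once, so no single step between measured compounds can be read from them.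

Compound 3 `Cc1ccc(=O)n(CCC(=N)S)n1` is the untested variant of compound 1 with one change: a group of 3 heavy atoms (1 carbon, 1 nitrogen, 1 sulfur; no ring) in place of a group of 2 heavy atoms (1 carbon, 1 nitrogen; no ring), on a saturated chain carbon, two bonds along the chain from an aromatic nitrogen. Only the two numbers above are available to judge it. Compound 2 carries the same entering group on its chain and gives the higher number, so for compound 3 a modest rise from the very low value of compound 1 is expected rather than none, with the step of a number 7.8 percentage points higher from compound 1 to compound 3 (within the scatter) taken as the estimate. For compound 3 in this assay the expected value is 8%, within 0% to 25%.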

Compound 3, a percentage reported as inhibition, in the whole organism at one dose (the size of the read-out at that dose, not a potency): 73.9%
The estimate for compound 3 lay 65.9 percentage points below the measured number; measured number outside the range, above it.
By their numbers in this assay, from the lowest: compound 1; then compound 2; then compound 3.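

At the saturated chain carbon, two bonds along the chain from an aromatic nitrogen, the read-out proves highly sensitive to the group attached. In this assay, a group of 3 heavy atoms (1 carbon, 1 nitrogen, 1 sulfur) in place of cyano gives a number 73.7 percentage points higher from compound 1 to compound 3 (beyond the scatter), with the core of compound 1 unchanged, a single-place effect that the earlier pair, differing in several places, could not isolate. Nothing measured here explains the size of this step.

Open, as far as these compounds go, is how an amide, with oxygen in place of the sulfur, or a carboxylic acid would read at this position. Also open, from the compounds shown here alone, are whether a longer chain keeps the effect and whether the effect holds across other doses, since the read-out comes from one dose only.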